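Exchanging the Hydroxyamino Group in Compound 3 for a Larger One

A few compounds are considered here, and "the series" means these few. Any claim that something is new, unique, unknown or untested is made for them only; others in the source may bear on it.

Of the compounds shown here, three have been tested in a functional assay on MIA PaCa-2 cells (Homo sapiens) for inhibition; a lower number here means a stronger inhibitor, a higher number a weaker inhibitor. Compound 1 `CCC(C)C(NC(=O)n1nnc2ccccc21)C(=O)NCc1ccccc1` carries the group that will enter in compound 4 together with a smaller amide partner, and in this assay compound 1 reaches only a limit, > 100000 nM, not a number. Compound 2 `CC(C)C(NC(=O)NO)C(=O)NC1CCCCC1` carries a hydroxyamino group and a saturated ring as amide partner, and in this assay compound 2 also stops at a limit, > 100000 nM. Compound 3 `CCC(C)C(NC(=O)NO)C(=O)NC(c1ccccc1)c1ccccc1` keeps the hydroxyamino group on a larger amide partner, and in this assay compound 3 gives 63800 nM. That makes compound 3 the only one of the three with a measured number; the other two rest at the limit of > 100000 nM in this assay, at which 2 of the 3 values shown sit.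

Compound 4 `CCC(C)C(NC(=O)n1nnc2ccccc21)C(=O)NC(c1ccccc1)c1ccccc1` differs from compound 3 in one place: a group of 9 heavy atoms (6 carbon, 3 nitrogen; one five-membered aromatic ring with 3 hetero atoms, one six-membered aromatic ring of carbon only) in place of a group of 2 heavy atoms (1 nitrogen, 1 oxygen; no ring), on a carbonyl carbon. Within the data shown here, no two measured compounds differ in a single place, so no measured step shows what this exchange does on its own. Compound 1 and compound 3 differ in more than one place, so their values can only be set side by side, and neither is strong.

The step from compound 3 to compound 4 in this assay is expected to be a 1.3-fold higher number from compound 3 to compound 4 (0.10 log units; within the scatter), a weakening within or just beyond the scatter. Compound 4 is therefore expected to give about 80000 nM, somewhere between 20000 nM and 200000 nM.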

Compound 4, half-maximal inhibitory concentration: 69300 nM
Compound 4: the middle estimate sits 1.2-fold (0.06 log units) above what was measured; the measured number falls inside the stated range.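

In this assay, the exchange of the hydroxyamino group for the larger group with two aromatic rings, on the carbonyl carbon, can now be read on its own, and it gives a 1.1-fold higher number from compound 3 to compound 4 (0.04 log units; within the scatter). This position therefore accepts a much larger group in place of the hydroxyamino group without a change that can be told from the scatter, so the hydroxyamino group is not needed for the weak inhibition seen here. The second new step, phenyl in place of hydrogen on a saturated chain carbon bound to an amide-type nitrogen and an aromatic carbon, gives an at least 1.4-fold lower number from compound 1 to compound 4 (0.15 log units; that floor lies within the scatter), and this is only a floor because compound 1 reached a limit of the assay rather than a number: the limit of > 100000 nM in this assay, at which 2 of the 4 values shown sit.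

Going by these compounds, what remains open is whether any group on this carbonyl carbon, such as an amine, a methyl or a carboxylic acid, would move the value beyond the scatter. On these data alone, the true size of the phenyl step also remains unknown, as does whether either change would give strong inhibition on another core.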